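A few compounds are considered here, and "the series" means these few. Any claim that something is new, unique, unknown or untested is made for them only; others in the source may bear on it.

Compound 1 `Oc1ccc(-c2cc(-c3cccc(Cl)c3)nc(-c3ccccn3)c2)cc1` carries a 4-hydroxyphenyl group, a 3-chlorophenyl group and a pyridin-2-yl group on a shared core. In an ADME assay on HEK293 cells (Homo sapiens) for cytotoxicity, read by CCK-8 assay and cell counting, with a stated time of 2 days (on this read-out lower numbers stand for stronger inhibition and higher numbers for weaker inhibition), compound 1 gives 25400 nM. Compound 2 `Oc1ccc(-c2cc(-c3cccnc3)nc(-c3cccc(Cl)c3)c2)cc1` keeps that core with pyridin-3-yl in place of pyridin-2-yl, and in this assay compound 2 gives 25700 nM. For the measured compounds named here, the only measured step, a 1.0-fold higher number from compound 1 to compound 2 (0.01 log units; within the scatter), concerns the pyridine ring and stays within the scatter. Compound 3 `Oc1ccc(-c2cc(-c3ccncc3)nc(-c3cccc(Cl)c3)c2)cc1`, the pyridin-4-yl analogue, gives "not determined" (no result reported) in this assay, so no number is reported for it. Of the two numbers shown, compound 1 has the lower, but the gap to compound 2 lies within the scatter, so the two cannot be told apart.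

Compound 4 `Oc1ccc(-c2cc(-c3ccc(Cl)cc3)nc(-c3ccccn3)c2)cc1` differs from compound 1 in one place: 4-chlorophenyl in place of 3-chlorophenyl on an aromatic carbon. Going by the values given here, no measured step touches the chlorophenyl group, so the one known step bears on this change only indirectly, and nothing in the data points to a shift beyond the scatter in this assay. For compound 4 the expected step is a 1.0-fold lower number from compound 1 to compound 4 (0.01 log units; within the scatter). Compound 4 is therefore estimated at 25000 nM in this assay, with a range from 11000 nM to 55000 nM.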

Compound 4, half-maximal inhibitory concentration: 27200 nM
The estimate for compound 4 lay 1.1-fold (0.04 log units) below the measured number; the measured number falls inside the stated range.
By their numbers in this assay, from the lowest: compounds 1, 2 and 4 (each within the scatter of the next).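

Compound 1 and compound 2 differ only in the pyridine ring, whereas this pair tests the chlorophenyl group on the shared core. The step from 3-chlorophenyl to 4-chlorophenyl, a 1.1-fold higher number from compound 1 to compound 4 (0.03 log units; within the scatter), shows that the place of the chlorine on that ring makes no difference that can be read in this assay. No measurement shown here offers an explanation for this result.

Both chlorophenyl groups keep the same atoms, so the pair says nothing about replacing the chlorine itself. On these data alone, it remains open whether an amine, a carboxylic acid or a longer chain in place of the chlorine would give a step beyond the scatter.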